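This account rests on a few compounds, and the source may have more. Where it says the series, first, only, none or still open, it means among the compounds named here.

Among the measured compounds shown here, only two compounds have been measured so far. In a physicochemical assay for lipophilicity, using the shake flask method, in phosphate buffer, measured as octanol-water partition, with a stated time of 2 h, at pH 7.4, tested at 1 uM (a lower number here means a more polar compound, a higher number a more lipophilic compound), compound 1 `OC[C@H]1O[C@H](Oc2ccc(-n3ccc4c(OCc5ccccc5)cccc43)cc2Cl)[C@@H](O)[C@@H](O)[C@@H]1O` gives 2.7, and compound 2 `OC[C@H]1O[C@H](Oc2ccc(-n3ccc4cc(Cl)cnc43)cc2Cl)[C@@H](O)[C@@H](O)[C@@H]1O` gives 3.4. Compound 2 therefore holds the higher of the two numbers, and the gap between them lies beyond the scatter of repeat measurements.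

Compound 3 `N#Cc1cnc2c(ccn2-c2ccc(O[C@H]3O[C@H](CO)[C@@H](O)[C@H](O)[C@@H]3O)c(Cl)c2)c1` differs from compound 2 in one place: it has cyano in place of chloro on an aromatic carbon. For the measured compounds named here, no measured pair shows this swap, so the data offer no direct guide to its size, and what follows is a judgement from the structural change alone. A downward move in this assay is expected, large enough to stand beyond the scatter. The estimated step is a number 0.80 log units lower from compound 2 to compound 3 (beyond the scatter). Compound 3 is expected at 2.6, with a likely range of 2.2 to 3.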

Compound 3, distribution coefficient: 1.6
Estimate against measurement, compound 3: 1.00 log units above, outside the stated range (below it).
By their numbers in this assay, from the lowest: compound 3; then compound 1; then compound 2.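

In this assay, among the compounds shown here, putting cyano in place of chloro on an aromatic carbon of the six-membered aromatic ring with 1 nitrogen gives a number 1.80 log units lower from compound 2 to compound 3 (beyond the scatter), the first step between compounds that differ in one place. It shows that this position of the shared core can move the read-out strongly, even though the change is small on paper: 1 heavy atom leaves, 2 heavy atoms enter, 1 hydrogen-bond acceptor is gained, and no ring or net charge is involved. Nothing measured here explains the size of this step.

On these data alone, it remains open how far other groups at this position, such as an amine, a methoxy group or a carboxylic acid, would move the number. As far as these compounds go, it is also open whether the same swap would give a similar step elsewhere on the core.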